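From a Phenoxy Ketone to a Diethylamino Ketone

This account rests on a few compounds, and the source may have more. Where it says the series, first, only, none or still open, it means among the compounds named here.

Of the compounds shown here, two sharing one core have so far been measured in an assay on the whole organism (brain) for inhibition of Catechol O-methyltransferase (Mus musculus), with a stated time of 1 h, at a dose of 30 mg/kg by the oral route; on this read-out lower numbers stand for less inhibition and higher numbers for more inhibition at the one dose given (going by the name of the read-out). Compound 1 `O=C(CCN1CCN(c2ccccc2Cl)CC1)c1cc(O)c(O)c([N+](=O)[O-])c1` gives 6% in this assay. Compound 2 `O=C(COc1ccccc1)c1cc(O)c(O)c([N+](=O)[O-])c1` gives 39%, the higher of the two numbers shown; its nearest neighbour is compound 1, whose number lies lower by a gap beyond the scatter. Among the compounds with values here, no step between the two measured compounds differs in only one place, so their two values are simply set side by side.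

Compound 3 `CCN(CC)CCC(=O)c1cc(O)c(O)c([N+](=O)[O-])c1` has not yet been measured in this assay. It differs from compound 2 in one place: (diethylamino)methyl in place of phenoxy on a saturated chain carbon bound to a carbonyl carbon. The chain of compound 3 thus carries a nitrogen-containing group where compound 2 carries an oxygen-linked ring. The other compound with a nitrogen-containing group on its chain is compound 1, which gives 6%.

On that basis compound 3 is expected to fall, with an estimated step of a number 24 percentage points lower from compound 2 to compound 3 (beyond the scatter) downward and beyond the scatter. Compound 3 is estimated at 15%, within a range from 3% to 35%.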

Compound 3, a percentage reported as inhibition, in the whole organism at one dose (the size of the read-out at that dose, not a potency): 26%
Beside the measured number, compound 3's estimate is 11 percentage points below it, within the range that was stated.
By their numbers in this assay, from the lowest: compound 1; then compound 3; then compound 2.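

Within the data shown here, the first comparison that changes only this position is between phenoxy and (diethylamino)methyl on a saturated chain carbon bound to a carbonyl carbon, and in this assay it gives a number 13 percentage points lower from compound 2 to compound 3 (beyond the scatter). The six-membered aromatic ring of phenoxy is therefore not required for a measurable read-out at this one dose: with no ring in the entering group, compound 3 still gives 26%, so this position accepts an open-chain amine at some cost in this assay. Nothing among the available data accounts for the size of this step.

The change swaps the linking oxygen for a carbon-linked chain ending in nitrogen and removes the ring in a single move, so the compounds shown do not separate the contribution of each part. On these data alone, a phenylamino group in place of phenoxy would test the linking atom with the ring kept, while a piperidine or morpholine on the same chain would test a ring-closed amine, and how either would read in this assay remains open.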